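A few compounds are considered here, and "the series" means these few. Any claim that something is new, unique, unknown or untested is made for them only; others in the source may bear on it.

Measured in an assay on HEK293 cells for inhibition of Indoleamine 2,3-dioxygenase 1 (Homo sapiens), tested at 10 uM; on this read-out lower numbers stand for less inhibition and higher numbers for more inhibition at the one concentration tested (going by the name of the read-out): compound 1 `CCC(=O)N1CCc2cc(CNC(=O)c3cccc(F)c3)ccc21` gives 82%; compound 2 `CCCC(=O)NCc1ccc2c(c1)CCN2C(=O)CC(C)C` gives 64%; compound 3 `CC(=O)N1CCc2cc(CNC(=O)c3cccs3)ccc21` gives 72%.

Among these three, compound 1 stands where compound 3 sits within the scatter of it, while compound 2 sits beyond the scatter, lower. Compound 4 `CCC(=O)N1CCc2cc(CNC(=O)c3cccc(Cl)c3)ccc21` keeps the core of compound 1 and differs from it in one place: chloro in place of fluoro on an aromatic carbon. Among the measured compounds shown here, no step between measured compounds tests this kind of change, so the expectation rests on compound 1 alone. For compound 4 the expected step from compound 1 is small and of no clear direction, a number 2 percentage points higher from compound 1 to compound 4 (within the scatter), staying within the usual scatter. Compound 4 is therefore estimated at 84%, with a range from 70% to 95%.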

Compound 4, a percentage reported as inhibition, at one concentration (the size of the read-out at that concentration, not a potency): 77%
The estimate for compound 4 lay 7 percentage points above the measured number; low and high end bracket the measured number.
By their numbers in this assay, from the lowest: compounds 2, 3, 4 and 1 (each within the scatter of the next, the first and the last beyond it).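

In this assay, the first step read at this position, chloro in place of fluoro on an aromatic carbon meta to a large group, is a number 5 percentage points lower from compound 1 to compound 4 (within the scatter). The 3-fluorophenyl and 3-chlorophenyl forms of the shared core therefore cannot be told apart on this read-out, so this position accepts either halogen with no separable difference. No measurement shown gives a cause for this result. Whether a halogen is needed here at all remains open, as the compounds shown do not include a plain phenyl. On these data alone, what a methoxy group, an amine or a carboxylic acid would do at this place also remains open.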